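Sulfur-linked three-membered ring on the carbamate carbonyl

The compounds below may be only part of what the source reports. "The series", "measured", "known", "first", "only" and "open" are said of these compounds alone.

Measured so far in a functional assay on isolated protein for inhibition of Glucose-dependent insulinotropic receptor (Rattus norvegicus), read by HTRF and cAMP accumulation; a lower number here means that less compound is needed, a higher number that more compound is needed for the effect:
Compound 1, `Cc1nc(S(C)(=O)=O)ccc1Oc1ncnc(OC2CCN(C(=O)OC(C)(C)C#N)CC2)c1F`: compound 1 gives 1320 nM
Compound 2, `Cc1nc(S(C)(=O)=O)ccc1Oc1ncnc(OC2CCN(C(=O)O[C@@H](C)C(F)(F)F)CC2)c1F`: compound 2 gives 109 nM
Compound 3, `Cc1nc(S(C)(=O)=O)ccc1Oc1ncnc(OC2CCN(C(=O)SC(C)C)CC2)c1F`: compound 3 gives 41.3 nM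

Compound 1 stands highest of the three numbers: its nearest neighbour is compound 2, with a 12-fold lower number from compound 1 to compound 2 (1.08 log units; beyond the scatter), and the furthest is compound 3, with a 32-fold lower number from compound 1 to compound 3 (1.50 log units; beyond the scatter).

Compound 4, `Cc1nc(S(C)(=O)=O)ccc1Oc1ncnc(OC2CCN(C(=O)SC3CC3)CC2)c1F`, differs from compound 1 at the carbonyl carbon:
a group of 4 heavy atoms (3 carbon, 1 sulfur; one three-membered non-aromatic ring of carbon only) in place of a group of 6 heavy atoms (4 carbon, 1 nitrogen, 1 oxygen; no ring), on a carbonyl carbon

Among the compounds with values here, two measured steps bear on this. The step from compound 1 to compound 3 swaps the same leaving group for isopropylsulfanyl, another sulfur-linked group on the carbonyl carbon, and gives a 32-fold lower number from compound 1 to compound 3 (1.50 log units; beyond the scatter). The step from compound 2 to compound 3, a 2.6-fold lower number from compound 2 to compound 3 (0.42 log units; beyond the scatter), shows the sulfur-linked group also giving the lower number against the other oxygen-linked group. Compound 4 keeps sulfur on the carbonyl carbon as compound 3 does, with a three-membered ring of carbon only in place of the isopropyl. A large step in the same direction as from compound 1 to compound 3 is therefore expected in this assay, landing close to compound 3.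

Compound 4 is expected to give about 50 nM, within 20 nM to 150 nM. That estimate means a 26-fold lower number from compound 1 to compound 4 (1.42 log units; beyond the scatter).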

Compound 4, half-maximal effective concentration: 126 nM
Compound 4: the middle estimate sits 2.5-fold (0.40 log units) below what was measured; measured number inside the range.
By their numbers in this assay, from the lowest: compound 3; then compounds 2 and 4 (each within the scatter of the next); then compound 1.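

Working notes on the group on the carbonyl carbon, read in this assay: the change from 1-cyano-1-methylethoxy to the sulfur-linked cyclopropyl gives a 10-fold lower number from compound 1 to compound 4 (1.02 log units; beyond the scatter) and is a large step, so the drop from compound 1 is not confined to isopropylsulfanyl. With sulfur held fixed, the group on it still counts, as cyclopropyl in place of isopropyl gives a 3.1-fold higher number from compound 3 to compound 4 (0.48 log units; beyond the scatter) and takes back part of what isopropylsulfanyl gained. A sulfur link therefore does not by itself give a lower number than an oxygen link, since the comparison with 1-(trifluoromethyl)ethoxy gives a 1.2-fold higher number from compound 2 to compound 4 (0.06 log units; within the scatter) and leaves these two compounds inseparable, whereas compound 3 stands modestly clear of compound 2.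

No measurement shown here accounts for the gap between cyclopropyl and isopropyl on sulfur. Open, from the compounds shown here alone, is how far the group on sulfur can be taken, for example tert-butyl, a longer chain such as n-butyl or a phenyl ring, and whether an amine on the carbonyl carbon in place of the sulfur link would hold these numbers.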